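The source may hold more compounds than are shown below. What is called first, only, known or untested is meant among the compounds shown, and "the series" means these compounds.

Measured in a functional assay on MDA-MB-435 cells (Homo sapiens) for cytotoxicity, read by sulforhodamine B assay, with a stated time of 48 h, tested at 0.01 uM; on this read-out higher numbers stand for a weaker effect at the one concentration tested and lower numbers for a stronger effect:
compound 1 `COc1ccc(-c2cc(/C=C/C(=O)c3ccc(N)cc3)[nH]n2)cc1`: 97%
compound 2 `COc1cc(-c2cc(/C=C/C(=O)c3ccc(N)cc3)[nH]n2)cc(OC)c1OC`: 90%

Compound 2 stands at the lowest of these two numbers; the nearest is compound 1, whose value lies higher by a gap that is within the usual scatter, so no order between the two is drawn. Compound 3 `COc1ccc(-c2cc(/C=C/C(=O)c3ccc(N)cc3)[nH]n2)cc1OC` is not yet measured in this assay. It differs from compound 2 by hydrogen in place of methoxy on an aromatic carbon. Going by the values given here, no step between measured compounds covers this change. Since both measured values lie close together, the expected step in this assay is none beyond the scatter, in either direction. Compound 3 is therefore estimated at 94%, within 82% to 104%, an expected step of a number 4 percentage points higher from compound 2 to compound 3 (within the scatter).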

Compound 3, a percentage reported as activity, at one concentration (the size of the read-out at that concentration, not a potency): 91%
Compound 3: the middle estimate sits 3 percentage points above what was measured; the measured number falls inside the stated range.
By their numbers in this assay, from the lowest: compounds 2, 3 and 1 (each within the scatter of the next).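

In this assay, hydrogen in place of methoxy on an aromatic carbon gives a number 1 percentage points higher from compound 2 to compound 3 (within the scatter), and methoxy in place of hydrogen gives a number 6 percentage points lower from compound 1 to compound 3 (within the scatter). The two single changes now link all three methoxy-bearing compounds, and neither step separates its pair at this one concentration. No further measurement bears on these steps.

Going by these compounds, whether a hydroxy group, a fluorine atom or an amine on this carbon would move the read-out remains open. So does whether these compounds would separate at a higher concentration.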